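A few compounds are considered here, and "the series" means these few. Any claim that something is new, unique, unknown or untested is made for them only; others in the source may bear on it.

Measured compounds:
- compound 1, `N=C(S)CCCCCn1nc(-c2ccccc2)ccc1=O`, gives 91.4% in a functional assay on the whole organism (stomach) for inhibition, with Rattus norvegicus as the target, at a dose of 100 mg/kg by the intraduodenal route; a higher number here means more inhibition at the dose given (going by the name of the read-out), a lower number less inhibition
- compound 2, `N=C(S)CCn1nc(-c2ccccc2)ccc1=O`, gives 53.7% in this assay
- compound 3, `N=C(S)CCN1N=C(c2ccccc2)CCC1=O`, gives 38.2% in this assay

Compound 3 has the lowest number of the three in this assay; compound 2 stands nearest to it and compound 1 furthest, both gaps beyond the scatter. Compound 2 and compound 3 share the side chain, and the difference between their two cores is not broken down here.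

One structural change is seen twice. From compound 2 to compound 1 it is a group of 6 heavy atoms (4 carbon, 1 nitrogen, 1 sulfur; no ring) in place of a group of 3 heavy atoms (1 carbon, 1 nitrogen, 1 sulfur; no ring), on a saturated chain carbon, two bonds along the chain from an aromatic nitrogen, and it made the step of a number 37.7 percentage points higher from compound 2 to compound 1 (beyond the scatter). The unmeasured compound 4, `N=C(S)CCCCCN1N=C(c2ccccc2)CCC1=O`, arises from compound 3 by a group of 6 heavy atoms (4 carbon, 1 nitrogen, 1 sulfur; no ring) in place of a group of 3 heavy atoms (1 carbon, 1 nitrogen, 1 sulfur; no ring), on a saturated chain carbon, two bonds along the chain from an amide-type nitrogen in a ring. The group that leaves and the group that enters are the same as in the first pair; what differs around the place is the nitrogen two bonds along the chain, aromatic in compound 2 and amide-type in a ring in compound 3, so the two changes are the same kind of change, not the same.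

Going by the values given here, for compound 4 the expected step in this assay is a number 33.8 percentage points higher from compound 3 to compound 4 (beyond the scatter), set beside the earlier one and resting on compound 3 with its value 38.2% and on the rise seen in a number 37.7 percentage points higher from compound 2 to compound 1 (beyond the scatter); with only one prior instance on a different core, the range is kept wide. The estimate for compound 4 is 72%, between 50% and 92%.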

Compound 4, a percentage reported as inhibition, in the whole organism at one dose (the size of the read-out at that dose, not a potency): 48.5%
Estimate against measurement, compound 4: 23.5 percentage points above; the whole stated range lies above it.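

In this assay, the change to the group of 6 heavy atoms on the core of compound 3 gives a number 10.3 percentage points higher from compound 3 to compound 4 (beyond the scatter), so the direction of the earlier step holds on this second core. The size of the step does not carry over, and a rise read on one core is a poor guide to the rise on the other: the same change on two cores in this assay, a number 37.7 percentage points higher (beyond the scatter) from compound 2 to compound 1 and a number 10.3 percentage points higher (beyond the scatter) from compound 3 to compound 4, 27.4 percentage points apart, beyond the scatter of two such steps

Going by these compounds alone, this shows that the effect of the change depends on the core, but with only one pair on each core it gives no rule for a further core, and a reading at a single dose in the whole organism does not show why the two steps differ.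

Still open, on these data alone, is how the number moves with chain length on either core, as a longer chain or one of intermediate length could extend the rise, level off or reverse it. As far as these compounds go, it is also open whether an amine or a carboxylic acid in place of the group that changes here would give a step of the same direction on both cores.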